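The compounds below may be only part of what the source reports. "The series", "measured", "known", "first", "only" and "open" are said of these compounds alone.

Measured so far in a functional assay on A549 cells (Homo sapiens) for antiproliferative activity, read by MTT assay, with a stated time of 72 h; on this read-out higher numbers stand for weaker inhibition and lower numbers for stronger inhibition:
- compound 1 `COc1cc(-n2cnc3ccc(-c4ccccc4Cl)cc32)cc(OC)c1OC`: > 10000 nM, a limit of the assay and not a number
- compound 2 `COc1cc(-n2cnc3ccc(-c4ccc(C(C)=O)cc4)cc32)cc(OC)c1OC`: 2510 nM
- compound 3 `COc1cc(-n2cnc3ccc(-c4ccc(O)cc4)cc32)cc(OC)c1OC`: 5090 nM

Only compound 2 and compound 3 give actual numbers. Compound 3 holds the higher of the two, and the gap is a 2.0-fold higher number from compound 2 to compound 3 (0.31 log units; beyond the scatter).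

The next compound is compound 4 `COc1cc(-n2cnc3ccc(-c4ccc(F)cc4)cc32)cc(OC)c1OC`, with fluoro in place of hydroxy on an aromatic carbon, para to a large group: fluoro in place of hydroxy on an aromatic carbon. The same difference reads 4-hydroxyphenyl to 4-fluorophenyl.

Going by the values given here, no measured step makes this exact exchange. Among the compounds with values here, the closest is the one between compound 2 and compound 3, which changes the group at the same place. The steps out of compound 1, an at least 3.9-fold lower number from compound 1 to compound 2 (0.60 log units; beyond the scatter) and an at least 1.9-fold lower number from compound 1 to compound 3 (0.29 log units; that floor lies within the scatter), start from 2-chlorophenyl, a different kind of group, and bear on this change only loosely.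

Within the data shown here, since the one change seen at this place moved the number only as far as a 2.0-fold higher number from compound 2 to compound 3 (0.31 log units; beyond the scatter), no step beyond the scatter is expected in this assay. The expected size is a 1.1-fold lower number from compound 3 to compound 4 (0.05 log units; within the scatter), with no firm direction. For compound 4 the estimated value is 4500 nM, with an expected range of 1500 nM to 12000 nM.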

Compound 4, half-maximal inhibitory concentration: 6740 nM
Estimate against measurement, compound 4: 1.5-fold (0.18 log units) below; measured number inside the range.
By their numbers in this assay, from the lowest: compound 2; then compounds 3 and 4 (each within the scatter of the next). At a limit, above all of these: compound 1.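

In this assay, fluoro in place of hydroxy on the aromatic carbon para to a large group takes away the hydrogen-bond donor and acceptor counted for hydroxy, yet the step is a 1.3-fold higher number from compound 3 to compound 4 (0.12 log units; within the scatter), so at this place the two groups cannot be told apart on this read-out. Acetyl now stands apart from a second group, with a 2.7-fold higher number from compound 2 to compound 4 (0.43 log units; beyond the scatter), so the gap seen earlier between compound 2 and compound 3 is not specific to hydroxy, and compound 2 is separated from both of the others by steps beyond the scatter. The step out of 2-chlorophenyl, an at least 1.4-fold lower number from compound 1 to compound 4 (0.17 log units; that floor lies within the scatter), adds only a floor that does not clear the scatter, so 4-fluorophenyl cannot yet be set apart from that group.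

On these data alone, how far compound 1 really lies from the others stays open, since compound 1 gives a limit of the assay and not a number: the limit of > 10000 nM in this assay, at which 1 of the 4 values shown sits. Also open, as far as these compounds go, is whether an amine, a carboxylic acid or a longer chain at this same place would read with acetyl or with hydroxy and fluoro.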